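The compounds below may be only part of what the source reports. "The series", "measured", "known", "first", "only" and "open" are said of these compounds alone.

Measured so far in a functional assay on MCF7 cells (Homo sapiens) for antiproliferative activity, read by MTT assay, with a stated time of 48 h (a lower number here means a stronger inhibitor, a higher number a weaker inhibitor), each reading a limit:
Compound 1 `COc1cc(-c2cccc3nc(-c4cccc(O)c4)oc23)cc(OC)c1OC` gives > 25000 nM as a limit
Compound 2 `COc1ccc(-c2cccc3nc(-c4ccc5cc[nH]c5c4)oc23)c(OC)c1OC` gives > 25000 nM as a limit
Compound 3 `COc1ccc(-c2nc3c(-c4cc(OC)c(OC)c(OC)c4)cccc3o2)cc1OC` gives > 25000 nM as a limit

Within the data shown here, compound 3 therefore has no number, only a limit, and it stands with the other two: the series so far offers the limit of > 25000 nM in this assay, at which 3 of the 3 values shown sit, and no measured value beyond that.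

Compound 4 `COc1ccc(-c2nc3c(-c4cc(OC)c(OC)c(OC)c4)cccc3o2)cc1F` differs from compound 3 on one aromatic carbon, ortho to a methoxy group and meta to a large group. There, fluoro stands in place of methoxy, which turns 3,4-dimethoxyphenyl to 3-fluoro-4-methoxyphenyl (fluoro in place of methoxy on an aromatic carbon).

Among the measured compounds shown here, no measured pair shows what a single change of this kind does in this assay for these compounds. Compound 4 is expected to stay close to compound 3, and another limit is the likeliest report. The expected change is (a number no higher from compound 3 to compound 4 (the limit leaves the size open)), with nothing beyond the scatter and no set direction. Compound 4 is estimated at 25000 nM with an expected range from 9000 nM to 50000 nM for this reading.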

Compound 4, half-maximal inhibitory concentration: > 25000 nM
Compound 4: a limit, no number; the forecaster's own chance of this, stated with the estimate: 70%; the middle value sits exactly at the limit.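

Among these compounds, compound 3 and compound 4 each give only a limit, not a number, in this assay, so no step between them can be read. The compounds shown leave open what any change on the shared core does to this reading, for all stand at one limit: the limit of > 25000 nM in this assay, at which 4 of the 4 values shown sit.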